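The source may report more compounds than this note shows. Statements on the series, on what has been measured and on what is new or still open speak of the compounds shown alone.

- Compound 1 `O=C1/C(=C\c2ccc(Br)cc2)C(c2ccccc2)Oc2ccccc21`: 4.71
- Compound 2 `O=C1/C(=C\c2ccc(O)cc2)COc2ccccc21`: 2.92

In a physicochemical assay for lipophilicity, read by HPLC (on this read-out lower numbers stand for lower lipophilicity and higher numbers for higher lipophilicity), compound 2 gives 2.92, the lower of the two numbers. Compound 1, at 4.71, lies higher by a gap beyond the usual scatter, but the two compounds differ in more than one place. Compound 3 `O=C1/C(=C/c2ccc(O)cc2)COc2ccccc21` is the next to be measured, and the change from compound 2 is this: the two compounds have the same atoms and bonds and differ only in configuration as drawn: 1 of 1 stereo elements differ; a double bond is drawn Z in compound 2 and E in compound 3. Among the measured compounds shown here, no measured pair yet shows what such a change does in this assay, so the expectation is only a judgement. The expected change is small, a number 0.08 log units higher from compound 2 to compound 3 (within the scatter), and not beyond the scatter. For compound 3 the estimated value is 3, with an expected range of 2.6 to 3.4.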

Compound 3, partition coefficient: 3.1
Compound 3: the middle estimate sits 0.10 log units below what was measured; the measured number falls inside the stated range.
By their numbers in this assay, from the lowest: compounds 2 and 3 (each within the scatter of the next); then compound 1.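

Compounds 1 and 2 differ in more than one place, so they could not isolate any single change. In this assay, this pair does isolate one, and switching the double bond from Z to E gives a number 0.18 log units higher from compound 2 to compound 3 (within the scatter), so the two configurations cannot be told apart on this read-out. This is the only structural difference behind that step: the fact that compounds 2 and 3 differ only in the configuration as drawn

As far as these compounds go, whether the configuration matters as little with an amine or a carboxylic acid in place of the hydroxyl group remains open. So does the separate contribution of the bromine in compound 1.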